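Swapping Benzyl for 4-Cyanophenyl on the Ring Nitrogen

A few compounds are considered here, and "the series" means these few. Any claim that something is new, unique, unknown or untested is made for them only; others in the source may bear on it.

Three compounds share one core: compound 1 is `CC1CCN(C(=S)SCc2ccc(C(=O)Nc3ccccc3N)cc2)CC1`, compound 2 is `Nc1ccccc1NC(=O)c1ccc(CSC(=S)N2CCN(C(c3ccccc3)c3ccccc3)CC2)cc1`, and compound 3 is `Nc1ccccc1NC(=O)c1ccc(CSC(=S)N2CCN(Cc3ccccc3)CC2)cc1`. In a functional assay on MGC-803 cells (Homo sapiens) for antiproliferative activity, read by CCK-8 assay, with a stated time of 72 h, tested at 2 uM (a higher number here means a stronger effect of the compound at the concentration tested, a lower number a weaker effect), compound 1 gives 28.1%, compound 2 gives 9.8%, and compound 3 gives 18.1%. Compound 3 stands second highest of the three numbers; its nearest neighbour is compound 2 and its furthest is compound 1, and neither gap goes beyond the scatter. For the measured compounds named here, the single measured step, a number 8.3 percentage points higher from compound 2 to compound 3 (within the scatter), is hydrogen in place of phenyl on a saturated chain carbon bound to an amine nitrogen in a ring and an aromatic carbon, and it stays within the scatter.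

Compound 4, `N#Cc1ccc(N2CCN(C(=S)SCc3ccc(C(=O)Nc4ccccc4N)cc3)CC2)cc1`, differs from compound 3 by 4-cyanophenyl in place of benzyl on an amine nitrogen in a ring. Going by the values given here, no measured step replaces the group on the amine nitrogen in a ring by an aromatic one, so the only guide is that the one step measured lay within the scatter. The step of a number 0.1 percentage points lower from compound 3 to compound 4 (within the scatter) is therefore expected to stay within the scatter as well. Compound 4 is expected to give 18%, with a range from 5% to 32%.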

Compound 4, a percentage reported as inhibition, at one concentration (the size of the read-out at that concentration, not a potency): 34.5%
Compound 4: the middle estimate sits 16.5 percentage points below what was measured, outside the stated range (above it).
By their numbers in this assay, from the lowest: compounds 2, 3, 1 and 4 (each within the scatter of the next, the first and the last beyond it).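

In this assay, for the compounds shown here, the change of benzyl to 4-cyanophenyl on the amine nitrogen in a ring gives a number 16.4 percentage points higher from compound 3 to compound 4 (beyond the scatter) and is the first step to pass beyond the scatter. The earlier step on this side of the molecule, a number 8.3 percentage points higher from compound 2 to compound 3 (within the scatter), did not do so, which means the group on this nitrogen can shift the read-out measurably at the concentration tested. No measurement here explains why this swap raises the number.

The swap removes the chain carbon of benzyl and adds the nitrile in one move, so the compounds shown cannot assign the step to either change. Plain phenyl on the same nitrogen would separate the two, and 4-methoxyphenyl would show whether the nitrile itself is needed.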